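The compounds below may be only part of what the source reports. "The series", "measured", "known", "first", "only" and "open" are said of these compounds alone.

Three compounds sharing one core differ only in the ring that hangs from an oxygen on the aromatic ring. Compound 1 `COc1cc(C(=O)N(C)C)ccc1Nc1nc(OC2CCCCC2)c2cc[nH]c2n1` carries a cyclohexyl there, compound 2 `COc1cc(C(=O)N(C)C)ccc1Nc1nc(O[C@H]2CCOC(C)(C)C2)c2cc[nH]c2n1` a 2,2-dimethyloxan-4-yl and compound 3 `COc1cc(C(=O)N(C)C)ccc1Nc1nc(OC2CCOCC2)c2cc[nH]c2n1` an oxan-4-yl. In a functional assay on CAL-51 cells (Homo sapiens) for antiproliferative activity, read by luminescence and CellTiter-Glo, with a stated time of 3 days (a lower number here means a stronger inhibitor, a higher number a weaker inhibitor), compound 1 gives 190 nM, compound 2 gives 131 nM and compound 3 gives 198 nM. Compound 3 has the highest of the three numbers, but its gaps to the others are small: a 1.0-fold higher number from compound 1 to compound 3 (0.02 log units; within the scatter) and a 1.5-fold higher number from compound 2 to compound 3 (0.18 log units; within the scatter), so none of the three can be told apart with confidence in this assay.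

Compound 4 `COc1cc(C(=O)N(C)C)ccc1Nc1nc(O[C@H]2CC[C@@](C)(O)CC2)c2cc[nH]c2n1` continues this series at the same oxygen. Its change from compound 3 is 4-hydroxy-4-methylcyclohexyl in place of oxan-4-yl on an oxygen on an aromatic ring. Among the compounds with values here, the steps that bear on it are the two swaps already seen at this position, a 1.0-fold higher number from compound 1 to compound 3 (0.02 log units; within the scatter) and a 1.5-fold higher number from compound 2 to compound 3 (0.18 log units; within the scatter), both within the scatter; exchanging one six-membered ring for another here has so far moved nothing. Within the data shown here, the entering ring brings a hydroxy and a methyl on an all-carbon ring, which has no close precedent among the measured compounds, so the expectation rests on the flatness seen so far. Compound 4 is therefore expected to give about 170 nM, between 75 nM and 380 nM, an expected step of a 1.2-fold lower number from compound 3 to compound 4 (0.07 log units; within the scatter) that stays within the scatter.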

Compound 4, half-maximal inhibitory concentration: 44 nM
Compound 4: middle estimate off by 3.9-fold (0.59 log units), on the high side; measured number below the stated range.
By their numbers in this assay, from the lowest: compound 4; then compounds 2, 1 and 3 (each within the scatter of the next).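

In this assay the ring on this oxygen turns out to matter after all: the 4-hydroxy-4-methylcyclohexyl group separates compound 4 from all three earlier compounds by more than the scatter, with (a 4.5-fold lower number from compound 3 to compound 4 (0.65 log units; beyond the scatter)) , (a 3.0-fold lower number from compound 2 to compound 4 (0.47 log units; beyond the scatter)) and (a 4.3-fold lower number from compound 1 to compound 4 (0.64 log units; beyond the scatter)) , which makes compound 4 the strongest inhibitor of the four. Swaps among cyclohexyl, 2,2-dimethyloxan-4-yl and oxan-4-yl gave no hint of this, and the comparison with compound 1 shows that an all-carbon ring alone does not produce the gain, since compound 4 differs from it only by the hydroxy and methyl added to that ring. Nothing available here accounts for the gain in activity.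

The hydroxy and the methyl arrive together, so the compounds shown cannot say what each contributes, and a 4-hydroxycyclohexyl or a 4-methylcyclohexyl group would be needed to separate them. Also open, as far as these compounds go, are the reversed arrangement at the two defined stereocentres and whether a methoxy or an amine could stand in place of the hydroxy.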